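A few compounds are considered here, and "the series" means these few. Any claim that something is new, unique, unknown or untested is made for them only; others in the source may bear on it.

Measured so far in a functional assay on Jurkat cells (Homo sapiens); a lower number here means a stronger inhibitor, a higher number a weaker inhibitor:
- compound 1 `C[C@H](NC(=O)C(=O)NCc1ccc(Cl)cc1)C(=O)N[C@@H](CC(=O)O)C(=O)COc1c(F)c(F)cc(F)c1F` gives 8.4 nM
- compound 2 `Cc1cccc(CNC(=O)C(=O)N[C@@H](C)C(=O)N[C@@H](CC(=O)O)C(=O)COc2c(F)c(F)cc(F)c2F)c1` gives 127 nM

Of the two, compound 2 is the weaker inhibitor, at 127 nM. Compound 3 `Cc1cccc(CNC(=O)C(=O)N[C@@H](C)C(=O)N[C@@H](CC(=O)O)C(=O)COc2c(F)c(F)cc(F)c2F)c1C` differs from it by methyl in place of hydrogen on an aromatic carbon, a methyl in place of hydrogen on an aromatic carbon. For the measured compounds named here, only one measured step concerns this ring: a 15-fold higher number from compound 1 to compound 2 (1.18 log units; beyond the scatter), a large step with 3-methylphenyl in place of 4-chlorophenyl. It shows that this assay responds to changes on this ring, but it does not give the direction for an added methyl. A smaller step is therefore expected, leaning only slightly towards a lower number, and the estimated step is a 1.4-fold lower number from compound 2 to compound 3 (0.15 log units; within the scatter). For compound 3 the expected value is 90 nM, within an estimated range of 25 nM to 320 nM.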

Compound 3, half-maximal inhibitory concentration: 102 nM
Compound 3: the middle estimate sits 1.1-fold (0.05 log units) below what was measured, within the range that was stated.
By their numbers in this assay, from the lowest: compound 1; then compounds 3 and 2 (each within the scatter of the next).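

In this assay a methyl on this aromatic carbon, ortho to a large group and ortho to a methyl group, is tolerated: a 1.2-fold lower number from compound 2 to compound 3 (0.10 log units; within the scatter) lies within the scatter, so compound 2 and compound 3 cannot be told apart. The 2,3-dimethylphenyl ring still leaves a 12-fold higher number from compound 1 to compound 3 (1.08 log units; beyond the scatter) as a large step beyond the scatter, so this added methyl does not restore what the 4-chlorophenyl ring gives. Open remains how a fluorine, a methoxy group or an amine on this ring would read in this assay and whether any of them would come near compound 1. No measurement at hand explains these steps.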